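This account rests on a few compounds, and the source may have more. Where it says the series, first, only, none or still open, it means among the compounds named here.

Among the measured compounds shown here, compound 2 `Cc1ccc(NC(=O)c2ccc(C(F)(F)F)cc2)cc1-n1cc(-c2cnc3cccnn23)cn1` is one of two compounds with results in a functional assay on K562 cells (Homo sapiens) for antiproliferative activity, read by CCK-8 assay, with a stated time of 24 h; a lower number here means a stronger inhibitor, a higher number a weaker inhibitor; in this assay compound 2 gives 10500 nM, the only plain number in the set. Compound 1 `Cc1ccc(NC(=O)c2cccc(C(F)(F)F)c2)cc1-n1cc(-c2cnc3cccnn23)cn1` is the other. In this assay compound 1 gives < 2 nM, which is a limit of the assay rather than a number. For the measured compounds named here, the single measured step, an at least 5200-fold higher number from compound 1 to compound 2 (3.72 log units; beyond the scatter), shows how much the number rises when the trifluoromethyl group is moved on the ring attached to the carbonyl carbon, although its size is tied to the limit at which compound 1 sits (the limit of < 2 nM in this assay, at which 1 of the 2 values shown sits).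

Compound 3 `Cc1ccc(NC(=O)c2cccc(Cl)c2)cc1-n1cc(-c2cnc3cccnn23)cn1` is not yet measured. It differs from compound 2 in this way: 3-chlorophenyl in place of 4-(trifluoromethyl)phenyl on a carbonyl carbon. Because the measured step of an at least 5200-fold higher number from compound 1 to compound 2 (3.72 log units; beyond the scatter) was large, and compound 3 carries its substituent at the same ring position as compound 1, a large fall in the number is expected, a 1100-fold lower number from compound 2 to compound 3 (3.02 log units; beyond the scatter). Compound 3 is therefore estimated at 10 nM, with a range from 1.5 nM to 120 nM.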

Compound 3, half-maximal inhibitory concentration: 5080 nM
Compound 3: the middle estimate sits 510-fold (2.71 log units) below what was measured; the measured number lies above the stated range.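

Exchanging 4-(trifluoromethyl)phenyl for 3-chlorophenyl gives only a 2.1-fold lower number from compound 2 to compound 3 (0.32 log units; beyond the scatter) in this assay, so having a substituent at the ring position shared with compound 1 does not by itself bring back the strength of compound 1. Chloro in place of trifluoromethyl on an aromatic carbon gives an at least 2500-fold higher number from compound 1 to compound 3 (3.40 log units; beyond the scatter), which shows that at this position the identity of the group matters, not only where it sits. The size of that step is tied to compound 1, whose value is a limit and not a number: the limit of < 2 nM in this assay, at which 1 of the 3 values shown sits.

From the compounds shown here alone, how far compound 1 truly lies past its limit stays open. Also open, going by these compounds, is whether a methoxy group, a nitrile or an amine in place of the chloro of compound 3 would behave more like trifluoromethyl or like chloro.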